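Swapping the amide-nitrogen group of compound 3

The compounds below may be only part of what the source reports. "The series", "measured", "known", "first", "only" and "open" are said of these compounds alone.

Compounds and values in a functional assay on HeLa cells (Homo sapiens) for inhibition, read by MTT assay, with a stated time of 48 h (a lower number here means a stronger inhibitor, a higher number a weaker inhibitor), so far:
compound 1 `COc1ccc2c(=O)c(/C=C/C(=O)Nc3cccc(C)c3)coc2c1` | > 100000 nM
compound 2 `O=C(/C=C/c1coc2cc(O)ccc2c1=O)NCc1ccccc1` | > 100000 nM
compound 3 `COc1ccc2c(=O)c(/C=C/C(=O)Nc3ccccc3Cl)coc2c1` | 22400 nM
compound 4 `COc1ccc2c(=O)c(/C=C/C(=O)NCc3ccccc3F)coc2c1` | not yet measured

Compound 1 stands at > 100000 nM, which is a limit of the assay. Compound 2 stands at > 100000 nM, also a limit. Among the measured compounds shown here, compound 3, at 22400 nM, holds the only true number in the set. The remaining readings rest on the limit of > 100000 nM in this assay, at which 2 of the 3 values shown sit, and give no number.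

The next change puts 2-fluorobenzyl in place of 2-chlorophenyl on an amide-type nitrogen, counted as 2-fluorobenzyl in place of 2-chlorophenyl on an amide-type nitrogen in full. For the measured compounds named here, the one measured step at this same nitrogen is an at least 4.4-fold lower number from compound 1 to compound 3 (0.64 log units; beyond the scatter), so the read-out has already responded to a swap there. A step toward a higher number is expected in this assay, smaller than that one, and a reading at the limit remains quite possible. The expected move is a 2.2-fold higher number from compound 3 to compound 4 (0.35 log units; beyond the scatter) as estimated here. For compound 4 the estimate is 50000 nM, with an expected range from 16000 nM to 100000 nM in this assay.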

Compound 4, half-maximal inhibitory concentration: > 100000 nM
Compound 4 gave a limit, no number (the forecaster's own chance of this, stated with the estimate: 45%); middle value at least 2.0-fold (0.30 log units) away from the limit.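

In this assay, putting 2-fluorobenzyl in place of 2-chlorophenyl on the amide-type nitrogen gives an at least 4.4-fold higher number from compound 3 to compound 4 (0.64 log units; beyond the scatter). Together with an at least 4.4-fold lower number from compound 1 to compound 3 (0.64 log units; beyond the scatter), this leaves 2-chlorophenyl as the only group at this nitrogen with a true number, as both groups compared with it give a limit. The step between compound 1 and compound 4 cannot be read, so 3-methylphenyl and 2-fluorobenzyl cannot be ordered.

The change alters both the halogen and the link to the ring, from phenyl to benzyl, so a 2-fluorophenyl or 2-chlorobenzyl group on this nitrogen would be needed to separate the two. The true size of both steps also stays open, as most of the series rests on one limit: the limit of > 100000 nM in this assay, at which 3 of the 4 values shown sit.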